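This account rests on a few compounds, and the source may have more. Where it says the series, first, only, none or still open, it means among the compounds named here.

Working notes on the series. The shared core of compound 1 `COc1ccc(C(=O)Nc2cccc(-c3oc4cc(-c5ccc(F)cc5)ccc4c(=O)c3O)c2)cc1` carries an amide whose acyl aryl is varied across the set. In a functional assay on GTL 16 cells for antiproliferative activity against GTL 16 cell line (Homo sapiens), read by CCK-8 assay, with a stated time of 72 h (on this read-out lower numbers stand for stronger inhibition and higher numbers for weaker inhibition), compound 1 gives 21100 nM. Compound 2 `COc1ccccc1C(=O)Nc1cccc(-c2oc3cc(-c4ccc(F)cc4)ccc3c(=O)c2O)c1` gives 6370 nM, and compound 3 `O=C(Nc1cccc(-c2oc3cc(-c4ccc(F)cc4)ccc3c(=O)c2O)c1)c1ccc(Cl)nc1` gives 7520 nM. Among the three numbers compound 3 stands second highest; its nearer neighbour lies within the scatter (a 1.2-fold higher number from compound 2 to compound 3 (0.07 log units; within the scatter)) and its further one well beyond it (a 2.8-fold lower number from compound 1 to compound 3 (0.45 log units; beyond the scatter)); the exchange of the acyl aryl between the other two gave a 3.3-fold lower number from compound 1 to compound 2 (0.52 log units; beyond the scatter).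

Compound 4 `CCCc1ccc(C(=O)Nc2cccc(-c3oc4cc(-c5ccc(F)cc5)ccc4c(=O)c3O)c2)cc1` continues the same exchange at the carbonyl carbon: 4-propylphenyl in place of 6-chloropyridin-3-yl on a carbonyl carbon. Within the data shown here, all three measured steps concern this very group, so they are the only guide. The one 4-substituted phenyl acyl measured so far, in compound 1, gave the highest number of the set, whereas compound 2 and compound 3 with other acyl groups sit lower. On that basis a step back toward the number of compound 1 is expected, that is a 1.9-fold higher number from compound 3 to compound 4 (0.27 log units; within the scatter) in this assay, of moderate size. For compound 4 the estimate is 14000 nM, within 5000 nM to 40000 nM.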

Compound 4, half-maximal inhibitory concentration: 20400 nM
Compound 4: the middle estimate sits 1.5-fold (0.16 log units) below what was measured, and the stated range covers the measured number.
By their numbers in this assay, from the lowest: compounds 2 and 3 (each within the scatter of the next); then compounds 4 and 1 (each within the scatter of the next).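

In this assay, propyl in place of methoxy on an aromatic carbon gives a 1.0-fold lower number from compound 1 to compound 4 (0.01 log units; within the scatter) and so does not separate the two 4-substituted phenyl acyl groups, whose different atoms at that aromatic carbon leave the number within the scatter. The same grouping holds against the other two acyl groups, with a 2.7-fold higher number from compound 3 to compound 4 (0.43 log units; beyond the scatter) and a 3.2-fold higher number from compound 2 to compound 4 (0.51 log units; beyond the scatter) both beyond the scatter; this pattern rests on compound 1 and compound 4 alone, and no compound shown goes against it. Nothing on hand gives a reason for this grouping.

Open, going by these compounds, is whether an amine, a carboxylic acid or a longer chain in place of propyl on the aromatic carbon would stay within the scatter of compound 4. Also open, on these data alone, is whether 2-propylphenyl on the carbonyl carbon would fall in line with compound 2 or compound 4.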